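The source may report more compounds than this note shows. Statements on the series, on what has been measured and on what is new or still open speak of the compounds shown alone.

Of the compounds shown here, three built on one shared core have been tested in an assay on isolated protein for binding affinity to leukotriene B4 receptor 1 (Homo sapiens), tested at 1 uM; a higher number here means more inhibition at the concentration tested (going by the name of the read-out), a lower number less inhibition. Compound 1 `C=CCc1cc(C(C)=O)c(O)cc1OCCCCCCCCCCC#N` gives 14%, the second highest of the three numbers. Compound 2 `CCc1cc(C(C)=O)c(O)cc1OCCCCCCCC(C)(C)C#N` gives 29%, and compound 3 `CCCc1cc(C(C)=O)c(O)cc1OCCCCC(=O)O` gives 0%, so compound 1 stands beyond the scatter from both of them, above compound 3 and below compound 2. Compound 4 `C=CCc1cc(C(C)=O)c(O)cc1OCCCCCC(=O)OC` has not yet been measured. It differs from compound 1 in one place: methoxycarbonyl in place of 5-cyanopentyl on a saturated chain carbon, five bonds along the chain from an oxygen on an aromatic ring. Compound 3, which likewise carries no nitrile, gives the lowest of the three numbers, and on that basis the step of a number 10 percentage points lower from compound 1 to compound 4 (within the scatter) is expected to be a fall beyond the scatter in this assay. Compound 4 is estimated to give about 4%, within a range from 0% to 18%.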

Compound 4, a percentage reported as inhibition, at one concentration (the size of the read-out at that concentration, not a potency): 65%
Beside the measured number, compound 4's estimate is 61 percentage points below it; measured number above the stated range.
By their numbers in this assay, from the lowest: compound 3; then compound 1; then compound 2; then compound 4.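

In this assay, methoxycarbonyl in place of 5-cyanopentyl, on a saturated chain carbon five bonds along the chain from an oxygen on an aromatic ring, gives a number 51 percentage points higher from compound 1 to compound 4 (beyond the scatter). The chain end at this position therefore matters strongly, and a nitrile there is not required for a high reading.

This single change alters both the end group and the size of the substituent, and an amide on the same chain could help tell these apart. Nothing measured here explains the rise.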